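Urea aryl swap in the triazole series: compound 4

The source may report more compounds than this note shows. Statements on the series, on what has been measured and on what is new or still open speak of the compounds shown alone.

Measured compounds:
compound 1, `CCCCc1cn(-c2ccc(NC(=O)Nc3ccc(C)nc3)cc2)nn1`, 1500 nM
compound 2, `CC(C)Cc1cn(-c2ccc(NC(=O)Nc3ccccc3F)cc2)nn1`, 120 nM
compound 3, `CCCCc1cn(-c2ccc(NC(=O)Nc3ccccc3F)cc2)nn1`, 600 nM

In an assay on isolated protein for inhibition of ATP-dependent RNA helicase DDX3X (Homo sapiens) (a lower number here means a stronger inhibitor, a higher number a weaker inhibitor), compound 2 gives 120 nM, the lowest number of the three; compound 3 stands nearest at a 5.0-fold higher number from compound 2 to compound 3 (0.70 log units; beyond the scatter), and compound 1 is furthest, giving 1500 nM. Compound 4, `CC(C)Cc1cn(-c2ccc(NC(=O)Nc3cccc(F)c3)cc2)nn1`, is not yet measured. It differs from compound 2 by 3-fluorophenyl in place of 2-fluorophenyl on an amide-type nitrogen.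

Going by the values given here, no measured step moves the fluorine on the urea aryl ring, so the change has no direct precedent here. Among the compounds with values here, the only step on the urea nitrogen is a 2.5-fold lower number from compound 1 to compound 3 (0.40 log units; beyond the scatter), which swaps the whole aryl group rather than the fluorine position; the other step, a 5.0-fold higher number from compound 2 to compound 3 (0.70 log units; beyond the scatter), is on the chain and does not bear on the urea side. Both steps are modest, so a modest step at most is expected for compound 4 in this assay, with direction open; the working expectation is a slight loss of potency, a step of a 1.8-fold higher number from compound 2 to compound 4 (0.26 log units; within the scatter), though a result within the scatter of compound 2 would not be surprising.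

Compound 4 is therefore estimated at 220 nM in this assay, with a range from 70 nM to 700 nM.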

Compound 4, half-maximal inhibitory concentration: 200 nM
Beside the measured number, compound 4's estimate is 1.1-fold (0.04 log units) above it; the measured number falls inside the stated range.
By their numbers in this assay, from the lowest: compounds 2 and 4 (each within the scatter of the next); then compound 3; then compound 1.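

In this assay, going by these compounds alone, the fluorine on the urea aryl ring is moved for the first time with the rest of the structure held fixed, and the step reads a 1.7-fold higher number from compound 2 to compound 4 (0.22 log units; within the scatter), so compound 2 and compound 4 cannot be told apart in this assay. Within the data shown here, the earlier urea-side comparison, a 2.5-fold lower number from compound 1 to compound 3 (0.40 log units; beyond the scatter), exchanged the whole aryl group and lay beyond the scatter, as did the chain step, a 5.0-fold higher number from compound 2 to compound 3 (0.70 log units; beyond the scatter), whereas 3-fluorophenyl in place of 2-fluorophenyl on this amide-type nitrogen is the only step that stays within it. With the isobutyl-bearing core of compound 2 held constant, either of these two fluorophenyl groups is therefore compatible with a number close to that of compound 2, but no measurement at hand accounts for this result.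

Going by these compounds, whether the same fluorine move would read the same way on the chain of compound 3 remains open. Also open, on these data alone, is how this assay would respond to an unsubstituted phenyl on this nitrogen, or to a chlorine atom or a methoxy group in place of the fluorine.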